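A few compounds are considered here, and "the series" means these few. Any claim that something is new, unique, unknown or untested is made for them only; others in the source may bear on it.

Three compounds share one core and differ only in the aromatic group attached to it. Compound 1 `COc1cc(C(=O)c2sc(-c3cccs3)cc2N)cc(OC)c1OC` gives 9.8 nM in a functional assay on L1210 cells (Mus musculus) for antiproliferative activity; a lower number here means a stronger inhibitor, a higher number a weaker inhibitor. Compound 2 `COc1cc(C(=O)c2sc(-c3ccc(F)cc3)cc2N)cc(OC)c1OC` gives 20 nM in this assay, and compound 3 `COc1cc(C(=O)c2sc(-c3cc(OC)c(OC)c(OC)c3)cc2N)cc(OC)c1OC` gives 2300 nM in this assay. Among these three numbers compound 2 stands second highest: its nearest neighbour is compound 1, while compound 3 lies far above it. For the measured compounds named here, the one single-point step recorded, a 2.0-fold higher number from compound 1 to compound 2 (0.31 log units; beyond the scatter), is a modest one.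

Compound 4 `CCOc1ccc(-c2cc(N)c(C(=O)c3cc(OC)c(OC)c(OC)c3)s2)cc1` has not yet been measured. It differs from compound 2 as follows: ethoxy in place of fluoro on an aromatic carbon. Going by the values given here, no measured step exchanges a fluoro for an ethoxy, so the guidance is indirect. The step of a 2.0-fold higher number from compound 1 to compound 2 (0.31 log units; beyond the scatter) shows that changing the aromatic group can move the number only modestly, whereas compound 3 with its 2300 nM shows that a different aromatic group can also push the number far higher. The expectation is therefore a step in this assay of modest size at most, a 1.3-fold higher number from compound 2 to compound 4 (0.10 log units; within the scatter), with the direction uncertain. Compound 4 is estimated at 25 nM, within a range from 5 nM to 150 nM.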

Compound 4, half-maximal inhibitory concentration: 590 nM
Compound 4: middle estimate off by 24-fold (1.37 log units), on the low side, and the stated range ends below it.
By their numbers in this assay, from the lowest: compound 1; then compound 2; then compound 4; then compound 3.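

In this assay, replacing fluoro with ethoxy on the six-membered aromatic ring, para to a large group, gives a 30-fold higher number from compound 2 to compound 4 (1.47 log units; beyond the scatter), the first case in which a change to a single substituent on this ring, with the ring itself kept, moves the number by a large step. The 4-ethoxyphenyl group also stands far from the thiophen-2-yl group, with a 60-fold higher number from compound 1 to compound 4 (1.78 log units; beyond the scatter), so that replacing one aromatic group with another at this place is not always the modest change seen in a 2.0-fold higher number from compound 1 to compound 2 (0.31 log units; beyond the scatter). Nothing shown here accounts for the size of these steps.

The compounds shown leave open whether the large step follows the ether oxygen or the length of the chain. A methoxy, an ethyl or a propoxy group at this place would separate the two.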